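A few compounds are considered here, and "the series" means these few. Any claim that something is new, unique, unknown or untested is made for them only; others in the source may bear on it.

Compound 1 `CC(C)=CC[C@@H](OC(=O)c1ccco1)C1=CC(=O)c2c(O)ccc(O)c2C1=O` in a functional assay on DU-145 cells (Homo sapiens) for cytotoxicity, read by MTT assay (a higher number here means a weaker inhibitor, a lower number a stronger inhibitor), gives > 100000 nM, which is a limit of the assay.
Compound 2 `CCCCC(CC(=O)O[C@H](CC=C(C)C)C1=CC(=O)c2c(O)ccc(O)c2C1=O)OC(C)=O` gives 67700 nM.
Compound 3 `CC(C)=CC[C@@H](OC(=O)C1CCCO1)C1=CC(=O)c2c(O)ccc(O)c2C1=O` gives 10500 nM.

Of the two plain numbers, compound 2 stands highest; its nearest neighbour is compound 3, and the step of a 6.4-fold lower number from compound 2 to compound 3 (0.81 log units; beyond the scatter) separates them. Compound 4 `CCCCC(C)(O)CC(=O)O[C@H](CC=C(C)C)C1=CC(=O)c2c(O)ccc(O)c2C1=O` has not been measured. It differs from compound 2 in that (1-hydroxy-1-methylpentyl in place of 1-acetoxypentyl on a saturated chain carbon bound to a carbonyl carbon). Among the compounds with values here, no measured step touches only that chain carbon: the steps of an at least 1.4-fold lower number from compound 1 to compound 2 (0.16 log units; that floor lies within the scatter) and a 6.4-fold lower number from compound 2 to compound 3 (0.81 log units; beyond the scatter) each exchange the whole acyl group, and the limit of > 100000 nM in this assay, at which 1 of the 3 values shown sits, leaves the first of them open-ended. The change from compound 2 to compound 4 is therefore expected to give no step beyond the scatter, a 1.1-fold lower number from compound 2 to compound 4 (0.05 log units; within the scatter). Compound 4 is estimated at 60000 nM, within 20000 nM to 150000 nM.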

Compound 4, half-maximal inhibitory concentration: 76500 nM
Beside the measured number, compound 4's estimate is 1.3-fold (0.11 log units) below it, within the range that was stated.
By their numbers in this assay, from the lowest: compound 3; then compounds 2 and 4 (each within the scatter of the next). At a limit, above all of these: compound 1.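

Replacing 1-acetoxypentyl with 1-hydroxy-1-methylpentyl on a saturated chain carbon bound to a carbonyl carbon gives a 1.1-fold higher number from compound 2 to compound 4 (0.05 log units; within the scatter) in this assay, so this exchange separates the two compounds by no more than the scatter. The oxolan-2-yl ester stays apart from the new chain too, with a 7.3-fold higher number from compound 3 to compound 4 (0.86 log units; beyond the scatter) beyond the scatter. The exchange of furan-2-yl for 2-hydroxy-2-methylhexyl on a carbonyl carbon can be read only as a floor (an at least 1.3-fold lower number from compound 1 to compound 4 (0.11 log units; that floor lies within the scatter)), because one end of it is a limit: the limit of > 100000 nM in this assay, at which 1 of the 4 values shown sits.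

Going by these compounds, whether an amine or a carboxylic acid on that chain carbon would give a step beyond the scatter remains open.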